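Catechol replaces bromophenyl on the shared core

The compounds below may be only part of what the source reports. "The series", "measured", "known", "first", "only" and "open" are said of these compounds alone.

Among the compounds with values here, compound 3 `COc1ccc(/C=C2\CCC/C(=C\c3cccc(Br)c3)C2=O)cc1OC` is the only member of the series with a number in a functional assay on A549 cells (Homo sapiens) for cytotoxicity, read by MTT assay, with a stated time of 72 h (a higher number here means a weaker inhibitor, a lower number a stronger inhibitor), where compound 3 gives 12800 nM. Compound 1 `COc1cccc(/C=C2\CCC/C(=C\c3ccccc3Cl)C2=O)c1OC` reaches only the limit of > 20000 nM in this assay. Compound 2 `COc1cccc(/C=C2\CCC/C(=C\c3cccc(Cl)c3)C2=O)c1OC` likewise sits at the limit of > 20000 nM in this assay. Within the data shown here, the step from compound 1 to compound 2 is a step that the two limits leave unreadable from compound 1 to compound 2, so the only measured pair yields no readable size; this rests on (the limit of > 20000 nM in this assay, at which 2 of the 3 values shown sit).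

Compound 4 `COc1ccc(/C=C2\CCC/C(=C\c3ccc(O)c(O)c3)C2=O)cc1OC` differs from compound 3 by 3,4-dihydroxyphenyl in place of 3-bromophenyl on a double-bonded chain carbon bound to a double-bonded ring carbon. Among the measured compounds shown here, no measured step touches a change of this kind, and the two limits give no direction either; the expectation therefore rests on compound 3 alone as the sole anchor.

Compound 4 is estimated at 9000 nM in this assay, within a range of 2500 nM to 25000 nM. The step from compound 3 to compound 4 is thus expected to be a 1.4-fold lower number from compound 3 to compound 4 (0.15 log units; within the scatter), a change not expected to exceed the scatter.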

Compound 4, half-maximal inhibitory concentration: > 20000 nM
Compound 4 was reported as a limit; the forecaster's own chance of this, stated with the estimate: 30%; middle value at least 2.2-fold (0.34 log units) from the limit.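

In this assay, within the data shown here, 3,4-dihydroxyphenyl in place of 3-bromophenyl gives an at least 1.5-fold higher number from compound 3 to compound 4 (0.19 log units; that floor lies within the scatter), the only step with a readable direction. Compound 4 gives > 20000 nM, which is a limit and not a number. At this place, on a double-bonded chain carbon bound to a double-bonded ring carbon, the entering group with its two hydrogen-bond donors brings no readable gain over 3-bromophenyl, and compound 3 keeps the only number in the series: the limit of > 20000 nM in this assay, at which 3 of the 4 values shown sit.

As far as these compounds go, whether the step from the bromine-bearing compound to the dihydroxy compound exceeds the scatter stays open. Also open, from the compounds shown here alone, is how a single hydroxyl group, an amine or a carboxylic acid at this place would read against compound 3 in this assay.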